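Swapping the aryl group on an acetoxyethyl enone

A few compounds are considered here, and "the series" means these few. Any claim that something is new, unique, unknown or untested is made for them only; others in the source may bear on it.

Four compounds share a core built around a methoxyphenyl ketone joined to a double-bonded chain. Compound 1 `COc1ccc(C(=O)/C(=C/c2ccccc2Cl)COC(=O)c2ccccc2)cc1` carries a 2-chlorophenyl on the chain and a benzoate ester; in a functional assay on MCF7 cells (Homo sapiens) for inhibition, read by XTT assay, with a stated time of 48 h (a higher number here means a weaker inhibitor, a lower number a stronger inhibitor), compound 1 gives 9000 nM. Compound 2 `CCC(/C=C(\CCOC(C)=O)C(=O)c1ccc(OC)cc1)CC` replaces the aryl group with pentan-3-yl and carries an acetoxyethyl chain; in this assay compound 2 gives only a limit, > 100000 nM. Compound 3 `COc1ccc(C(=O)/C(=C/c2ccc([N+](=O)[O-])cc2)CCOC(C)=O)cc1` keeps that chain with a 4-nitrophenyl; in this assay compound 3 also gives only a limit, > 100000 nM. The step from pentan-3-yl to 4-nitrophenyl is therefore a step that the two limits leave unreadable from compound 2 to compound 3. Compound 3 thus stands at the edge of what this assay reports, as noted by the limit of > 100000 nM in this assay, at which 2 of the 3 values shown sit.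

Compound 4 `COc1ccc(C(=O)/C(=C/c2ccccc2Cl)CCOC(C)=O)cc1` arises from compound 3 by 2-chlorophenyl in place of 4-nitrophenyl on a double-bonded chain carbon bound to a double-bonded chain carbon. Among the compounds with values here, no measured step speaks directly to this change; only compound 1, which carries the same 2-chlorophenyl but a different ester chain, shows a number at all. Compound 4 is therefore expected near 40000 nM, with a range from 8000 nM to 150000 nM, and the step from compound 3 to compound 4 is estimated as an at least 2.5-fold lower number from compound 3 to compound 4 (0.39 log units; beyond the scatter).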

Compound 4, half-maximal inhibitory concentration: > 100000 nM
Compound 4: only a limit was reported; the forecaster's own chance of this, stated with the estimate: 45%; at least 2.5-fold (0.39 log units) between middle value and limit.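

Placing 2-chlorophenyl on the acetoxyethyl chain does not lift the series off the limit, and the steps from compound 2 and from compound 3 to compound 4 cannot be read, because all three compounds sit at that limit: the limit of > 100000 nM in this assay, at which 3 of the 4 values shown sit.

Compound 1 and compound 4 share the 2-chlorophenyl and differ only in the ester chain, with acetoxymethyl in place of benzoyloxy on a saturated chain carbon bound to a double-bonded chain carbon. Within the data shown here, this gives the first readable step in this assay, an at least 11-fold higher number from compound 1 to compound 4 (1.04 log units; beyond the scatter), so the 2-chlorophenyl alone does not secure a measurable value.

From the compounds shown here alone, how far compound 2, compound 3 and compound 4 differ beyond the limit stays unknown. The compounds shown also leave open whether a simple amine or a carboxylic acid at the end of this chain would give a readable value.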